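Anilino series on the shared core: bromo for methyl

A few compounds are considered here, and "the series" means these few. Any claim that something is new, unique, unknown or untested is made for them only; others in the source may bear on it.

Compound 3 `Cc1ccc(NC2=CC(=O)c3c(nc4n3[C@H]3OC[C@@H](O)[C@H]3OC4)C2=O)cc1` carries a (4-methylphenyl)amino group on the shared core. In a functional assay on ECa-109 cells for inhibition, with ECa-109 cell line (Homo sapiens) as the target, read by sulforhodamine B assay (on this read-out lower numbers stand for stronger inhibition and higher numbers for weaker inhibition), compound 3 gives only a limit, > 4000 nM, and no number. Its closest measured neighbour is compound 1 `O=C1C(Nc2cccc(Cl)c2)=CC(=O)c2c1nc1n2[C@H]2OC[C@@H](O)[C@H]2OC1`, which in this assay gives 3080 nM. The step of an at least 1.2-fold higher number from compound 1 to compound 3 (0.11 log units; that floor lies within the scatter) therefore cannot be read as a real change. Compound 2 `O=C1C(NC2CCCC2)=CC(=O)c2c1nc1n2[C@H]2OC[C@@H](O)[C@H]2OC1` also gives only a limit in this assay, > 16000 nM. The step of an at least 5.1-fold higher number from compound 1 to compound 2 (0.71 log units; beyond the scatter) marks the cyclopentyl group as the weaker choice on the amine nitrogen, while the step that the two limits leave unreadable from compound 2 to compound 3 stays unreadable because both ends are limits.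

Compound 4 `O=C1C(Nc2ccc(Br)cc2)=CC(=O)c2c1nc1n2[C@H]2OC[C@@H](O)[C@H]2OC1` differs from compound 3 by bromo in place of methyl on an aromatic carbon. For the measured compounds named here, no measured step in this assay changes a substituent on the aryl ring of the anilino group at this position, so the size of the step is not anchored; the 3-chlorophenyl analogue, compound 1, gives a measurable number, which keeps the expectation near the upper end of the measurable range. For compound 4 the estimated step is a step that the limit leaves unreadable from compound 3 to compound 4, a change not expected to exceed the scatter. Compound 4 is expected to give about 5000 nM in this assay, within 1500 nM to 16000 nM.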

Compound 4, half-maximal inhibitory concentration: 1980 nM
Estimate against measurement, compound 4: 2.5-fold (0.40 log units) above; the range from low to high includes it.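

In this assay the step of a 1.6-fold lower number from compound 1 to compound 4 (0.19 log units; within the scatter) leaves 4-bromophenyl and 3-chlorophenyl on the amine nitrogen indistinguishable, so the series now has two aryl groups with measured numbers. Going by these compounds, the step of an at least 8.0-fold lower number from compound 2 to compound 4 (0.90 log units; beyond the scatter) shows a second aryl group clearly ahead of cyclopentyl on that nitrogen, although that gap rests on a limit and its full size is unknown. The step of an at least 2.0-fold lower number from compound 3 to compound 4 (0.30 log units; that floor lies within the scatter) does not establish a real gain for bromo in place of methyl, and compound 3 remains a limit rather than a number: the limit of > 4000 nM in this assay, at which 1 of the 4 values shown sits.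

The compounds shown do not separate the identity of the halogen from its place on the aryl ring. On these data alone, it also remains open how a methoxy group or a carboxylic acid on that ring would read.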